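Aryl amide variation in the orexin type 2 series

A few compounds are considered here, and "the series" means these few. Any claim that something is new, unique, unknown or untested is made for them only; others in the source may bear on it.

In a functional assay on CHO-K1 cells for agonist activity at Orexin receptor type 2 (Homo sapiens), read by calcium flux (on this read-out higher numbers stand for larger maximal responses and lower numbers for smaller maximal responses), compound 2 `COc1ccc(C(=O)NCCNc2cccc(NS(=O)(=O)c3cc(-c4cccc(C(=O)N(C)C)c4)ccc3OC)c2)cc1` gives 94%, the highest of the two numbers shown, while compound 1 `COc1cccc(C(=O)NCCNc2cccc(NS(=O)(=O)c3cc(-c4cccc(C(=O)N(C)C)c4)ccc3OC)c2)c1` gives 54%. For the measured compounds named here, the one measured step, a number 40 percentage points higher from compound 1 to compound 2 (beyond the scatter), is large. Compound 3 `COc1ccc(-c2cccc(C(=O)N(C)C)c2)cc1S(=O)(=O)Nc1cccc(NCCNC(=O)c2ccccc2C)c1` differs from compound 2 by 2-methylphenyl in place of 4-methoxyphenyl on a carbonyl carbon. Going by the values given here, no measured step covers this change; the step from compound 1 to compound 2 shows only that the aryl amide substituent moves the maximal response strongly, so a sizeable step is expected, a fall judged more likely because compound 2 gives 94% as the top value here. Compound 3 is therefore estimated at 60%, range 30% to 95%, an expected step of a number 34 percentage points lower from compound 2 to compound 3 (beyond the scatter).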

Compound 3, largest response reached (Emax), in percent of the reference or control that the assay uses: 85%
For compound 3 the middle estimate is 25 percentage points below the measured one; the measured number falls inside the stated range.
By their numbers in this assay, from the lowest: compound 1; then compounds 3 and 2 (each within the scatter of the next).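

In this assay the 2-methylphenyl amide holds the high response seen with the 4-methoxyphenyl amide, with a number 9 percentage points lower from compound 2 to compound 3 (within the scatter), so a methoxy group on this aryl amide is not required for a high maximal response. With a number 31 percentage points higher from compound 1 to compound 3 (beyond the scatter), the low value among these three belongs to the 3-methoxyphenyl amide alone. No supporting data bear on why these aryl groups differ.

Still open, as far as these compounds go, is whether methyl and methoxy read alike when placed identically on the ring, since no single group is compared across ring placements apart from methoxy. Unsubstituted phenyl, 4-methylphenyl and a ring carrying a carboxylic acid would help to settle how far this tolerance extends.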